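The compounds below may be only part of what the source reports. "The series", "measured", "known", "first", "only" and "open" are said of these compounds alone.

Measured in a functional assay on HCT-116 cells (Homo sapiens) for inhibition, read by MTT assay, with a stated time of 48 h; a higher number here means a weaker inhibitor, a lower number a stronger inhibitor:
- compound 1 `COc1ccc(CN(C(=O)C=C(C)C)c2cc(OC)c(OC)c(OC)c2)cc1O`: 290 nM
- compound 2 `C/C=C/C(=O)N(Cc1ccc(OC)c(O)c1)c1cc(OC)c(OC)c(OC)c1`: 55 nM

Of these two, compound 2 holds the lower number, at 55 nM, so it is the stronger inhibitor of the pair. Its nearest and only neighbour is compound 1, at 290 nM.

Compound 3 `COc1ccc(CN(C(=O)CBr)c2cc(OC)c(OC)c(OC)c2)cc1O` is the next to be considered. Going from compound 2 to compound 3, the change is bromomethyl in place of prop-1-en-1-yl on a carbonyl carbon. In words, bromomethyl stands in place of prop-1-en-1-yl on a carbonyl carbon.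

Among the compounds with values here, only one measured step bears on this: a 5.3-fold lower number from compound 1 to compound 2 (0.72 log units; beyond the scatter), where prop-1-en-1-yl replaced 2-methylprop-1-en-1-yl on a carbonyl carbon. That step is modest but beyond the scatter, and it shows that a change on this carbonyl carbon can move the number. Within the data shown here, no measured compound carries bromomethyl, so the direction remains uncertain. Compound 2, at 55 nM, is the better of the two measured, so a modest rise in this assay is expected rather than a fall.

The expected change is a 2.2-fold higher number from compound 2 to compound 3 (0.34 log units; beyond the scatter). The estimate for compound 3 is 120 nM, with an expected range of 25 nM to 600 nM.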

Compound 3, half-maximal inhibitory concentration: 68 nM
Compound 3: middle estimate off by 1.8-fold (0.25 log units), on the high side; the range from low to high includes it.
By their numbers in this assay, from the lowest: compounds 2 and 3 (each within the scatter of the next); then compound 1.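

In this assay, the carbonyl carbon with its amide-type nitrogen accepts a quite different group with no reading of change: a 1.2-fold higher number from compound 2 to compound 3 (0.09 log units; within the scatter), so bromomethyl and prop-1-en-1-yl cannot be told apart here, although bromomethyl carries a bromine and has no double bond outside aromatic rings. The other new step, a 4.3-fold lower number from compound 1 to compound 3 (0.63 log units; beyond the scatter), runs the same way as a 5.3-fold lower number from compound 1 to compound 2 (0.72 log units; beyond the scatter), so among these three compounds it is 2-methylprop-1-en-1-yl that stands apart, and a double bond outside aromatic rings at this place is not needed to reach the lower numbers. Nothing available explains why the three compounds fall as they do.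

The compounds shown leave open whether the bromine itself counts for anything, a question that chloromethyl or plain methyl on the same carbonyl carbon would address. They also leave open how far this place stretches, since neither a longer chain nor a chain ending in an amine or a carboxylic acid appears among them.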